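A Chloro Substituent Enters the Core of Compound 3

A few compounds are considered here, and "the series" means these few. Any claim that something is new, unique, unknown or untested is made for them only; others in the source may bear on it.

Compound 3 `O=c1c(SC(=S)N2CCCC2)coc2ccccc12` stands at the highest of the three numbers in a functional assay on HEp-2 cells (Homo sapiens) for antiproliferative activity, read by MTT assay, with a stated time of 72 h (on this read-out lower numbers stand for stronger inhibition and higher numbers for weaker inhibition), where compound 3 gives 7400 nM. Its nearest neighbour is compound 1 `O=c1c(SC(=S)N2CCCCC2)coc2ccccc12`, which in this assay gives 5800 nM; the step of a 1.3-fold higher number from compound 1 to compound 3 (0.11 log units; within the scatter) lies within the scatter. Compound 2 `CC(C)N(C(=S)SCc1coc2ccccc2c1=O)C(C)C` lies furthest, giving 3000 nM in this assay. Compound 4 `O=c1c(SC(=S)N2CCCC2)coc2ccc(Cl)cc12` differs from compound 3 in one place: chloro in place of hydrogen on an aromatic carbon. Going by the values given here, no measured step touches the core; the single step on record concerns pyrrolidin-1-yl in place of piperidin-1-yl on a thiocarbonyl carbon and was small. With nothing pointing either way, the step is expected to be no change at the digits printed from compound 3 to compound 4 (within the scatter), none beyond the scatter. Compound 4 is therefore estimated in this assay at 7400 nM, between 3000 nM and 18000 nM.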

Compound 4, half-maximal inhibitory concentration: 26000 nM
Compound 4: middle estimate off by 3.5-fold (0.55 log units), on the low side; the whole stated range lies below it.
By their numbers in this assay, from the lowest: compounds 2, 1 and 3 (each within the scatter of the next, the first and the last beyond it); then compound 4.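

Chloro in place of hydrogen on an aromatic carbon of the shared core gives a 3.5-fold higher number from compound 3 to compound 4 (0.55 log units; beyond the scatter) in this assay and so weakens inhibition beyond the scatter. Going by these compounds alone, the only earlier step between compounds differing in one place, a 1.3-fold higher number from compound 1 to compound 3 (0.11 log units; within the scatter) on the thiocarbonyl carbon, stayed within the scatter, so this position on the core responds to a single added chlorine atom. No evidence on record bears on this step.

From the compounds shown here alone, whether fluoro or methoxy in the same place would also weaken inhibition remains open. So does whether chloro would have a similar effect on the core of compound 1.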